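The compounds below may be only part of what the source reports. "The series", "measured", "known", "first", "only" and "open" are said of these compounds alone.

Three compounds share one core. Compound 1 `O=C1CSC(c2cccc(Cl)c2)N1CCN1CCCCC1` gives 100% in an ADME assay on Vero cells (Chlorocebus sabaeus) for cytotoxicity, read by neutral red uptake, tested at 98 ug/mL; on this read-out lower numbers stand for a stronger effect and higher numbers for a weaker effect at the one concentration tested. Compound 2 `O=C1CSC(c2ccc(O)cc2)N1CCN1CCCCC1` gives 94% in this assay, and compound 3 `O=C1CSC(c2ccccc2[N+](=O)[O-])N1CCN1CCCCC1` gives 100% there. Among the compounds with values here, the one single-point step among them, a number 6 percentage points lower from compound 1 to compound 2 (within the scatter), lies within the scatter. Compound 3 stands level with compound 1 at the digits given, together the highest of the three numbers, and its gap to compound 2 is also within the scatter. Compound 4 `O=C1CSC(c2ccccc2Cl)N1CCN1CCCCC1` is not yet measured; it differs from compound 3 by chloro in place of nitro on an aromatic carbon. Within the data shown here, the only measured step that bears on this, a change of a group on the aromatic ring, stayed within the scatter, so no step beyond the scatter is expected in this assay. Compound 4 is therefore expected to give 98%, with a range from 88% to 105%, which would mean a number 2 percentage points lower from compound 3 to compound 4 (within the scatter).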

Compound 4, a percentage reported as activity, at one concentration (the size of the read-out at that concentration, not a potency): 94%
Beside the measured number, compound 4's estimate is 4 percentage points above it, and the stated range covers the measured number.
By their numbers in this assay, from the lowest: compounds 2, 4, 1 and 3 (each within the scatter of the next).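

In this assay, chloro in place of nitro on an aromatic carbon ortho to a large group gives a number 6 percentage points lower from compound 3 to compound 4 (within the scatter), so this position tolerates this exchange within the scatter. 2-Chlorophenyl in place of 3-chlorophenyl gives a number 6 percentage points lower from compound 1 to compound 4 (within the scatter), and 2-chlorophenyl in place of 4-hydroxyphenyl gives no change at the digits printed from compound 2 to compound 4 (within the scatter), so neither exchange separates these compounds. Nothing available here accounts for these results. On these data alone, whether an amine or a carboxylic acid on this aromatic carbon would also stay within the scatter remains open. As far as these compounds go, all four compounds were read at one concentration, so any difference at another concentration also remains open.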